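Amine side chain swap on a bromo-naphthyridine carboxamide series

This account rests on a few compounds, and the source may have more. Where it says the series, first, only, none or still open, it means among the compounds named here.

Measured so far:
compound 1 `C[C@@H](Nc1c(C(=O)NCc2ccc(F)cc2)nc(Br)c2cccnc12)c1ccccc1` — > 20000 nM
compound 2 `N[C@H]1CC[C@H](NC(=O)c2nc(Br)c3cccnc3c2NCc2ccc(F)cc2)CC1` — 6600 nM
compound 3 `CN(C)c1ccc(CNC(=O)c2nc(Br)c3cccnc3c2N[C@H]2CC[C@H](N)CC2)cc1` — 4000 nM

In a functional assay on MDA-MB-435 cells (Homo sapiens) for cytotoxicity, read by MTT assay, with a stated time of 72 h (a higher number here means a weaker inhibitor, a lower number a stronger inhibitor), compound 1 gives only a limit, > 20000 nM, and no number. Compound 2 gives 6600 nM in this assay. Compound 3 gives 4000 nM in this assay. Compound 1 thus stands at the limit, while compound 2 and compound 3 return measurable values; the gap between compound 2 and compound 3 is within the usual scatter, so neither is called stronger.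

The next compound is compound 4 `NCCCCCCNc1c(C(=O)NCc2ccc(F)cc2)nc(Br)c2cccnc12`. It differs from compound 1 in one place: 6-aminohexyl in place of 1-phenylethyl on a nitrogen on an aromatic ring.

Within the data shown here, no step between measured compounds is available for this change, so its size cannot be read from the data. Compound 2 and compound 3, which carry a different substituent on the same nitrogen, do give numbers in this assay; on that basis a step into the measurable range is expected. The step from compound 1 to compound 4 is estimated at an at least 2.5-fold lower number from compound 1 to compound 4 (0.39 log units; beyond the scatter), towards a stronger value. Compound 4 is expected to give about 8000 nM in this assay, within 3000 nM to 20000 nM.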

Compound 4, half-maximal inhibitory concentration: 6000 nM
Beside the measured number, compound 4's estimate is 1.3-fold (0.12 log units) above it, and the stated range covers the measured number.
By their numbers in this assay, from the lowest: compounds 3, 4 and 2 (each within the scatter of the next). At a limit, above all of these: compound 1.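

Swapping in 6-aminohexyl for 1-phenylethyl on a nitrogen on an aromatic ring gives an at least 3.3-fold lower number from compound 1 to compound 4 (0.52 log units; beyond the scatter) in this assay and provides the only readable step in the series, showing that the group on this nitrogen can move a compound off the limit. The change removes the six-membered aromatic ring and the defined stereocentre and brings in an open chain ending in an amine, so several features change in one step. Going by these compounds, the true size of the step stays unknown because compound 1 sits at a limit: the limit of > 20000 nM in this assay, at which 1 of the 4 values shown sits.

On these data alone, whether the step follows from the loss of the aromatic ring or from the gain of the terminal amine remains open. A plain hexyl chain or a shorter aminoalkyl chain on the same nitrogen would bear on that question.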